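The compounds below may be only part of what the source reports. "The series", "measured", "known", "first", "only" and "open" are said of these compounds alone.

In a functional assay on MCF7 cells (Homo sapiens) for cytotoxicity, read by MTT assay, with a stated time of 24 h, tested at 6.4 ug/mL (on this read-out lower numbers stand for a weaker effect and higher numbers for a stronger effect at the one concentration tested), compound 1 `Cc1nnc(SCC(=O)Nc2ccc(-c3nc(-c4ccccc4)c(-c4ccccc4)n3C)cc2)s1` gives 67.8%, compound 2 `Cn1c(-c2ccc(NC(=O)CSC3=NCCS3)cc2)nc(-c2ccccc2)c1-c1ccccc1` gives 18.6%, and compound 3 `CN(C)/C=C/N1CCN(CC(=O)Nc2ccc(-c3nc(-c4ccccc4)c(-c4ccccc4)n3C)cc2)CC1` gives 11.1%. Compound 3 thus stands lowest of the three: the step of a number 56.7 percentage points lower from compound 1 to compound 3 (beyond the scatter) is large and beyond the scatter, whereas the step of a number 7.5 percentage points lower from compound 2 to compound 3 (within the scatter) lies within the scatter, so compound 2 and compound 3 cannot be told apart on these numbers. The only large movement in the set, a number 49.2 percentage points lower from compound 1 to compound 2 (beyond the scatter), concerns the group on the sulfur of compound 1 and not the piperazine ring.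

Compound 4 `Cc1ccc(CN2CCN(CC(=O)Nc3ccc(-c4nc(-c5ccccc5)c(-c5ccccc5)n4C)cc3)CC2)cc1` differs from compound 3 in one place: 4-methylbenzyl in place of 2-(dimethylamino)ethenyl on an amine nitrogen in a ring. Among the compounds with values here, no measured step touches the substituent on this ring nitrogen, so the data give no direct guide for the size or direction of the change. Both measured steps away from compound 1 ended at low activity, and the two low compounds sit together within the scatter, which suggests the piperazine series stays modest.

On that basis compound 4 is expected to show a step of a number 6.9 percentage points higher from compound 3 to compound 4 (within the scatter) that stays within the scatter, with the estimate for compound 4 put at 18% in this assay, in a range from 5% to 45%.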

Compound 4, a percentage reported as activity, at one concentration (the size of the read-out at that concentration, not a potency): 21.8%
Compound 4: middle estimate off by 3.8 percentage points, on the low side; low and high end bracket the measured number.
By their numbers in this assay, from the lowest: compounds 3, 2 and 4 (each within the scatter of the next, the first and the last beyond it); then compound 1.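

On the ring nitrogen of the piperazine, this assay now gives a first direct reading: with 4-methylbenzyl in place of 2-(dimethylamino)ethenyl, the result is a number 10.7 percentage points higher from compound 3 to compound 4 (beyond the scatter), so the group on this nitrogen does shift the read-out, and the shift clears the usual scatter. The change is still small beside the exchange of the whole group on the saturated chain carbon, which gave a number 56.7 percentage points lower from compound 1 to compound 3 (beyond the scatter), so swapping the substituent on this nitrogen, at least for this pair, recovers only a small part of that distance. Nothing available explains why the carbon-only aromatic group, with its ring of six and no hydrogen-bond acceptor, differs from the open chain that carries a nitrogen.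

Within the data shown here, with only two groups compared on this nitrogen, it remains open whether the aromatic ring, its methyl or simply the larger group accounts for the step. Plain benzyl, 4-methoxybenzyl, pyridin-4-ylmethyl or a longer chain ending in a carboxylic acid on the same nitrogen would each separate these readings, and would show whether the trend continues at all.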